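A few compounds are considered here, and "the series" means these few. Any claim that something is new, unique, unknown or untested is made for them only; others in the source may bear on it.

Compound 1 `Cc1ccc(CN2CCC(CCN(Cc3ccc(-c4cccc(C#N)c4)cc3)C(=O)NC(C)C)CC2)cc1` and compound 2 `Cc1ccc(CN2CCC(CCN(Cc3ccc(-c4ccccc4)cc3)C(=O)NC(C)C)CC2)cc1` share the same core and differ only by a substituent on an aromatic carbon. Within the data shown here, in an in vitro functional assay on HEK293 cells for antagonist activity at melanin-concentrating hormone receptor 1 (Homo sapiens), read by GTPgammaS binding, with a stated time of 45 min (a higher number here means a weaker inhibitor, a lower number a stronger inhibitor), compound 1 gives 1010 nM and compound 2 gives 220 nM; the step of a 4.6-fold lower number from compound 1 to compound 2 (0.66 log units; beyond the scatter) is the only measured change so far. Compound 2 thus holds the lower of the two numbers in this assay, with compound 1 the nearest at a higher number and that gap beyond the scatter.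

Compound 3 `Cc1ccc(CN2CCC(CCN(Cc3ccc(-c4ccccc4)cc3)C(=O)NC(C)(C)CO)CC2)cc1` keeps the whole of compound 2 and carries one change: hydroxymethyl in place of hydrogen on a saturated chain carbon bound to an amide-type nitrogen and two saturated chain carbons. Among the measured compounds shown here, no measured step touches this part of the molecule; the single known step concerns a substituent on an aromatic carbon and gives no guide to a change at the isopropylcarbamoyl end. The expectation for compound 3 in this assay therefore rests on compound 2 alone, with a step of a 1.1-fold higher number from compound 2 to compound 3 (0.06 log units; within the scatter) expected to stay within the scatter. Compound 3 is estimated at 250 nM in this assay, with a range from 90 nM to 700 nM.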

Compound 3, antagonist equilibrium constant: 122 nM
Compound 3: the middle estimate sits 2.0-fold (0.31 log units) above what was measured; measured number inside the range.
By their numbers in this assay, from the lowest: compounds 3 and 2 (each within the scatter of the next); then compound 1.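

At the isopropylcarbamoyl end, hydroxymethyl in place of hydrogen on a saturated chain carbon bound to an amide-type nitrogen and two saturated chain carbons gives, in this assay, a 1.8-fold lower number from compound 2 to compound 3 (0.26 log units; within the scatter), so the two compounds cannot be told apart here. Among these compounds, this is the first reading at this end of the molecule, since the earlier step concerned only the cyano group on an aromatic carbon: isopropyl can give way to 1-(hydroxymethyl)-1-methylethyl, with its 2 added heavy atoms, 1 hydrogen-bond donor and 1 hydrogen-bond acceptor, without a step beyond the scatter. Nothing available explains why this step stays within the scatter.

The compounds shown leave open how an amine or a carboxylic acid in place of the hydroxyl would read in this assay, and whether a tert-butyl group, which has the added carbon but no oxygen, would read like compound 3. They also leave open whether the same change at this position would give a similar step when the cyano group of compound 1 is present.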